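Aminomethylpyridine in place of sulfamoylphenyl: a large recovery expected

This account rests on a few compounds, and the source may have more. Where it says the series, first, only, none or still open, it means among the compounds named here.

In an in vitro assay on HEK385-7 cells for displacement of a labelled ligand from prostaglandin D2 receptor 2 (Homo sapiens) (a higher number here means a weaker inhibitor, a lower number a stronger inhibitor), three compounds have been measured:
compound 1 `O=C(O)Cc1sc(C(c2ccc(F)cc2)c2ccc(F)cc2)nc1-c1ccnc(F)c1` gives 0.48 nM
compound 2 `O=C(O)Cc1sc(C(c2ccc(F)cc2)c2ccc(F)cc2)nc1-c1ccccc1` gives 16 nM
compound 3 `NS(=O)(=O)c1ccc(-c2nc(C(c3ccc(F)cc3)c3ccc(F)cc3)sc2CC(=O)O)cc1` gives 1500 nM

Compound 3 stands highest of the three; the steps leading to it are a 94-fold higher number from compound 2 to compound 3 (1.97 log units; beyond the scatter) and a 3100-fold higher number from compound 1 to compound 3 (3.49 log units; beyond the scatter). Compound 4 `Cc1cc(-c2nc(C(c3ccc(F)cc3)c3ccc(F)cc3)sc2CC(=O)O)cnc1N` arises from compound 3 by 6-amino-5-methylpyridin-3-yl in place of 4-sulfamoylphenyl on an aromatic carbon. Going by the values given here, two measured steps bear on this change. The sulfamoyl group disappears, which undoes the step of a 94-fold higher number from compound 2 to compound 3 (1.97 log units; beyond the scatter). A phenyl ring gives way to a pyridinyl ring, and in the measured set a 33-fold higher number from compound 1 to compound 2 (1.52 log units; beyond the scatter) ran the other way, so the reverse should help. Among the compounds with values here, the amino and methyl groups on the entering ring have no counterpart among the measured compounds, which leaves the size uncertain. A large drop in the number is therefore expected, roughly a 190-fold lower number from compound 3 to compound 4 (2.27 log units; beyond the scatter). Compound 4 is expected to give 8 nM, estimated within 1 nM to 60 nM.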

Compound 4, half-maximal inhibitory concentration: 880 nM
Beside the measured number, compound 4's estimate is 110-fold (2.04 log units) below it; measured number outside the range, above it.
By their numbers in this assay, from the lowest: compound 1; then compound 2; then compounds 4 and 3 (each within the scatter of the next).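

Exchanging 4-sulfamoylphenyl for 6-amino-5-methylpyridin-3-yl on this carbon, next to the ring nitrogen, brings no recovery, with a 1.7-fold lower number from compound 3 to compound 4 (0.23 log units; within the scatter). A pyridinyl ring here does not by itself give a low number: the entering group stays far behind both phenyl, with a 55-fold higher number from compound 2 to compound 4 (1.74 log units; beyond the scatter), and 2-fluoropyridin-4-yl, with a 1800-fold higher number from compound 1 to compound 4 (3.26 log units; beyond the scatter). Nothing available explains this outcome.

On these data alone, what the amino and methyl groups each contribute remains open. So does how a chloro or methoxy group on the pyridinyl ring would compare with the fluoro group of compound 1.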